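The source may report more compounds than this note shows. Statements on the series, on what has been measured and on what is new or still open speak of the compounds shown alone.

Values in a functional assay on MCF7 cells (Homo sapiens) for antiproliferative activity, read by sulforhodamine B assay; on this read-out higher numbers stand for weaker inhibition and lower numbers for stronger inhibition:
- compound 1 `O=C1NC(=O)c2ccc(I)cc2/C1=C/Nc1ccc(CN2CCCCC2)cc1`: 1000 nM
- compound 2 `CN1CCN(c2ccc(N/C=C3\C(=O)NC(=O)c4ccc(-c5ccoc5)cc43)cc2)CC1`: 1100 nM
- compound 3 `CN1CCN(c2ccc(N/C=C3\C(=O)NC(=O)c4ccc(-c5ccsc5)cc43)cc2)CC1`: 2300 nM

Compound 1 and compound 2 lie within the scatter of each other, while compound 3 has a higher number than compound 1, beyond the scatter. Compound 4 `O=C1NC(=O)c2ccc(-c3cccc(O)c3)cc2/C1=C/Nc1ccc(CN2CCCCC2)cc1` is unmeasured and differs from compound 1 by 3-hydroxyphenyl in place of iodo on an aromatic carbon, with 3-hydroxyphenyl in place of iodo on an aromatic carbon.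

Among the measured compounds shown here, only one measured step bears on this change: a 2.1-fold higher number from compound 2 to compound 3 (0.32 log units; beyond the scatter). It is modest, and it exchanges thiophen-3-yl for furan-3-yl, so it compares two ring groups rather than iodo with a ring group. For the measured compounds named here, no measured pair makes that comparison directly. Compound 2, which carries a ring group at this place, gives 1100 nM, close to the value of compound 1. No step beyond the scatter is therefore expected in this assay, and the data set no firm direction.

The expected step is a 1.3-fold lower number from compound 1 to compound 4 (0.10 log units; within the scatter). For compound 4 the estimated value is 800 nM, with an expected range of 250 nM to 2500 nM.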

Compound 4, half-maximal inhibitory concentration: 2000 nM
The estimate for compound 4 lay 2.5-fold (0.40 log units) below the measured number; the measured number falls inside the stated range.
By their numbers in this assay, from the lowest: compounds 1, 2, 4 and 3 (each within the scatter of the next, the first and the last beyond it).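

In this assay, among the compounds shown here, the first direct exchange at this position with the rest of the molecule held constant gives a 2.0-fold higher number from compound 1 to compound 4 (0.30 log units; within the scatter), so replacing iodo with 3-hydroxyphenyl produces no step beyond the scatter. For the compounds shown here, compounds 2 and 3 compared only two ring groups with each other, and they differ from compound 1 in more than one place; this pair sets a single iodine against a group of seven heavy atoms with an aromatic ring, a hydrogen-bond donor and a hydrogen-bond acceptor. The added size and these counted features therefore leave the read-out within the scatter in this one pair, and nothing available gives a reason for that result.

Still open, as far as these compounds go, is how a plain phenyl group would compare with 3-hydroxyphenyl here, and whether a carboxylic acid or a primary amine on that ring would give a step beyond the scatter. Also open, from the compounds shown here alone, is whether the same exchange would behave alike with the side chain of compound 2 in place of that of compound 1.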